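The source may hold more compounds than are shown below. What is called first, only, known or untested is meant among the compounds shown, and "the series" means these compounds.

Of the compounds shown here, two have been measured in a functional assay on 786-0 cells (Homo sapiens) for inhibition, read by sulforhodamine B assay, with a stated time of 48 h; a lower number here means a stronger inhibitor of growth, a higher number a weaker inhibitor of growth. Compound 1 `CC1=CC[C@H](C(C)(C)NC(=S)N/N=C/c2ccccc2)CC1` gives 67000 nM, and compound 2 `CC1=CC[C@H](C(C)(C)NC(=S)N/N=C/c2cccc(Cl)c2)CC1` gives 26900 nM. Compound 2 therefore holds the lower of the two numbers, the change from compound 1 being chloro in place of hydrogen on an aromatic carbon. Compound 3 `CC1=CC[C@H](C(C)(C)NC(=S)N/N=C/c2cccc([N+](=O)[O-])c2)CC1` has not yet been measured; it differs from compound 2 in one place, (nitro in place of chloro on an aromatic carbon), that is, nitro in place of chloro on an aromatic carbon. Among the compounds with values here, the only measured step that bears on this change is a 2.5-fold lower number from compound 1 to compound 2 (0.40 log units; beyond the scatter), which concerns a different swap at the same kind of position and shows that a group placed there gave a modestly lower number. The expectation for compound 3 in this assay is a number close to that of compound 2, with the step of a 1.1-fold lower number from compound 2 to compound 3 (0.03 log units; within the scatter) expected to be small and of uncertain direction. Compound 3 is estimated at 25000 nM, within a range from 9000 nM to 70000 nM.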

Compound 3, concentration for total growth inhibition: > 100000 nM
Compound 3: a limit, no number; the forecaster's own chance of this, stated with the estimate: 5%; middle value at least 4.0-fold (0.60 log units) from the limit.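

At this position, the choice of group matters and not only whether a group is present. In this assay nitro in place of chloro gives an at least 3.7-fold higher number from compound 2 to compound 3 (0.57 log units; beyond the scatter) so the lower number seen with chloro does not carry over to every group placed there. Nitro in place of hydrogen gives an at least 1.4-fold higher number from compound 1 to compound 3 (0.17 log units; that floor lies within the scatter) and since that floor lies within the scatter, nitro cannot yet be ranked against hydrogen. The value of compound 3 is a limit of the assay and not a number: the limit of > 100000 nM in this assay, at which 1 of the 3 values shown sits.

On these data alone, how far compound 3 really lies beyond that limit remains open. Also open is what an amine, a methoxy group or a carboxylic acid would do at this position on the ring, since only hydrogen, chloro and nitro are shown there.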